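A substituent swap on a weakly cytotoxic compound

The source may hold more compounds than are shown below. What is called first, only, known or untested is meant among the compounds shown, and "the series" means these compounds.

Measured so far in a functional assay on K562 cells (Homo sapiens) for cytotoxicity, read by MTT assay, with a stated time of 72 h; on this read-out higher numbers stand for weaker inhibition and lower numbers for stronger inhibition:
- compound 1 `COc1ccc(Nc2ccc3ccccc3n2)cc1`: 30000 nM
- compound 2 `CCc1ccc(Nc2nc3ccccc3cc2-c2ccccc2)cc1`: 99000 nM
- compound 3 `Fc1ccc(Nc2ccc3ccccc3n2)cc1`: 36000 nM

Among these three, compound 2 gives the highest number, 99000 nM, and its gap to each of the other two lies beyond the usual scatter of repeated measurements. Compound 4 `COc1cccc(Nc2nc3ccccc3cc2-c2ccccc2)c1` has not yet been measured. It keeps the core of compound 2 and changes one group: 3-methoxyphenyl in place of 4-ethylphenyl on a nitrogen on an aromatic ring.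

Within the data shown here, only one measured step involves a methoxy group, with fluoro in place of methoxy on an aromatic carbon: a 1.2-fold higher number from compound 1 to compound 3 (0.08 log units; within the scatter). This step is within the scatter, but it sits on a different core and swaps different groups, so it offers only weak guidance. Among the measured compounds shown here, no measured pair shows what happens when 4-ethylphenyl is replaced on the core of compound 2. With so little evidence and only a small measured step of a 1.2-fold higher number from compound 1 to compound 3 (0.08 log units; within the scatter) to go on, no clear shift in either direction is expected in this assay. The expected change is a 1.2-fold lower number from compound 2 to compound 4 (0.09 log units; within the scatter), which would not stand out from the scatter. For compound 4 the estimated value is 80000 nM, with an expected range from 35000 nM to 170000 nM.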

Compound 4, half-maximal inhibitory concentration: 76000 nM
Beside the measured number, compound 4's estimate is 1.1-fold (0.02 log units) above it; the measured number falls inside the stated range.
By their numbers in this assay, from the lowest: compounds 1 and 3 (each within the scatter of the next); then compounds 4 and 2 (each within the scatter of the next).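

Putting 3-methoxyphenyl in place of 4-ethylphenyl on a nitrogen on an aromatic ring gives, in this assay, a 1.3-fold lower number from compound 2 to compound 4 (0.11 log units; within the scatter). Among these compounds, this is the only measured change at this position on the core of compound 2, and it shows that a group with an oxygen and a hydrogen-bond acceptor can enter, with the heavy-atom count unchanged, without moving the number beyond the scatter. Nothing measured here speaks to why the number holds.

As far as these compounds go, both groups are aromatic rings of carbon only with no net charge, so it remains open whether an amine or a carboxylic acid on that ring, or a longer chain in place of the ring, would shift the number beyond the scatter. In addition, 4-ethylphenyl and 3-methoxyphenyl differ both in the group carried by the ring and in the numbered place where it sits, so this single step cannot separate those two changes.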